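The source may report more compounds than this note shows. Statements on the series, on what has been measured and on what is new or still open speak of the compounds shown alone.

Measured so far in a functional assay on FM3A cells (Mus musculus) for antiproliferative activity, with a stated time of 48 h; a higher number here means a weaker inhibitor, a lower number a stronger inhibitor

- compound 1 `C=C(Br)C(=O)Nc1ccc(/C=C/C(=O)c2ccccc2)cc1` gives 3900 nM
- compound 2 `C=C(Br)C(=O)Nc1ccc(/C=C/C(=O)c2ccc(F)cc2)cc1` gives 1200 nM
- compound 3 `C=C(Br)C(=O)Nc1ccc(/C=C/C(=O)c2ccc(I)cc2)cc1` gives 8300 nM

Compound 3 has the highest number of the three and is the weakest here, with a 2.1-fold higher number from compound 1 to compound 3 (0.33 log units; beyond the scatter) and a 6.9-fold higher number from compound 2 to compound 3 (0.84 log units; beyond the scatter) both beyond the scatter. The next change leads to compound 4 `C=C(Br)C(=O)Nc1ccc(/C=C/C(=O)c2cccs2)cc1` with thiophen-2-yl in place of 4-iodophenyl on a carbonyl carbon and the rest of the structure unchanged.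

Among the compounds with values here, no measured step exchanges the aromatic ring itself, so the evidence is indirect. Within the data shown here, two measured steps bear on the change: the modest iodo step a 2.1-fold higher number from compound 1 to compound 3 (0.33 log units; beyond the scatter) and the modest fluoro step a 3.3-fold lower number from compound 1 to compound 2 (0.51 log units; beyond the scatter) on the same aromatic ring. Compound 4 carries no iodo, and compound 1, which also lacks it, gives 3900 nM as the closest reference. A modest step toward a lower number is therefore expected in this assay and its size should resemble those two steps. On these data alone, the estimated change is a 2.8-fold lower number from compound 3 to compound 4 (0.44 log units; beyond the scatter) and the ring exchange remains untested. For compound 4 the expected value is 3000 nM with an estimated range from 1000 nM to 9000 nM in this measurement.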

Compound 4, half-maximal inhibitory concentration: 520 nM
Compound 4: the middle estimate sits 5.8-fold (0.76 log units) above what was measured; the whole stated range lies above it.
By their numbers in this assay, from the lowest: compound 4; then compound 2; then compound 1; then compound 3.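

Within the data shown here, exchanging the whole ring on the carbonyl carbon, rather than a substituent on the phenyl ring, produces the largest step so far: in this assay there is a 16-fold lower number from compound 3 to compound 4 (1.20 log units; beyond the scatter), and the comparison with the unsubstituted phenyl shows a 7.5-fold lower number from compound 1 to compound 4 (0.88 log units; beyond the scatter). The thiophen-2-yl ring also outperforms the best halogen-bearing ring, with a 2.3-fold lower number from compound 2 to compound 4 (0.36 log units; beyond the scatter), so compound 4 is the strongest of the four and this position tolerates a five-membered aromatic ring with a sulfur atom in place of a six-membered carbon ring. Nothing measured for these compounds accounts for the advantage of thiophen-2-yl over the phenyl rings.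

The compounds shown leave open whether the gain depends on the sulfur atom or its attachment through the 2-position, which furan-2-yl, thiophen-3-yl or pyridin-2-yl on the same carbonyl carbon would help to separate. They also leave open whether the thiophen-2-yl ring can be improved further by a substituent of its own, such as a chloro or methyl group, as the fluoro group changed the number on the phenyl ring.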